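Piperidinylacetamide in place of acetamide on the benzimidazole series

The source may report more compounds than this note shows. Statements on the series, on what has been measured and on what is new or still open speak of the compounds shown alone.

Compound 3 `CC(=O)Nc1ccc(-c2nc3ccccc3[nH]2)cc1` gives 100000 nM in an ADME assay on MT4 cells (Homo sapiens) for cytotoxicity, read by MTT assay, with a stated time of 96 h (a higher number here means that more compound is tolerated, a lower number that less compound is tolerated), the highest of the three numbers shown; its gap to compound 2 `O=C(CN1CCCCC1)Nc1ccc(-c2nc3cc(Cl)c(Cl)cc3[nH]2)cc1` at 54000 nM lies within the scatter, while compound 1 `O=C(CN1CCCCC1)Nc1ccc(-c2nc3cc(C(F)(F)F)ccc3[nH]2)cc1` at 6000 nM lies beyond it. Compound 4 `O=C(CN1CCCCC1)Nc1ccc(-c2nc3ccccc3[nH]2)cc1` is not yet measured. It differs from compound 3 by piperidin-1-yl in place of hydrogen on a saturated chain carbon bound to a carbonyl carbon. Going by the values given here, no step between measured compounds covers this change. Because compound 1 gives 6000 nM and compound 2 gives 54000 nM, both carrying the same piperidinylmethyl side chain, a step downward beyond the scatter, a 3.3-fold lower number from compound 3 to compound 4 (0.52 log units; beyond the scatter), is expected. Compound 4 is accordingly estimated at 30000 nM, with a range from 10000 nM to 100000 nM.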

Compound 4, half-maximal cytotoxic concentration: 31000 nM
The estimate for compound 4 lay 1.0-fold (0.01 log units) below the measured number; low and high end bracket the measured number.
By their numbers in this assay, from the lowest: compound 1; then compounds 4, 2 and 3 (each within the scatter of the next, the first and the last beyond it).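

In this assay, piperidin-1-yl in place of hydrogen on a saturated chain carbon bound to a carbonyl carbon gives a 3.2-fold lower number from compound 3 to compound 4 (0.51 log units; beyond the scatter), so this side chain moves the number with no other change on the shared core. Trifluoromethyl can now also be read alone: hydrogen in its place on an aromatic carbon gives a 5.2-fold higher number from compound 1 to compound 4 (0.71 log units; beyond the scatter). Nothing at hand bears on the cause of either step.

Still open, as far as these compounds go, is whether morpholine or a dimethylamino group on the same chain carbon gives a similar step. From the compounds shown here alone, a longer chain between the carbonyl and the piperidine also remains open.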